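This account rests on a few compounds, and the source may have more. Where it says the series, first, only, none or still open, it means among the compounds named here.

Compound 1 has the structure `Cc1cc(-c2ccc(Cl)cc2Cl)c(S(C)(=O)=O)cc1C(=O)N=C(N)N`; in a functional assay for inhibition of sodium/hydrogen exchanger (Oryctolagus cuniculus) (on this read-out lower numbers stand for stronger inhibition and higher numbers for weaker inhibition), compound 1 gives 42 nM.
Compound 2 has the structure `Cc1cc(Sc2ccc(Cl)cc2)c(S(C)(=O)=O)cc1C(=O)N=C(N)N`; in this assay compound 2 gives 19 nM.
Compound 3 has the structure `Cc1cc(Sc2ccccc2)c(S(C)(=O)=O)cc1C(=O)N=C(N)N`; in this assay compound 3 gives 14 nM.

Compound 3 sits at the low end of these three numbers. Its separation from compound 1 is a 3.0-fold lower number from compound 1 to compound 3 (0.48 log units; beyond the scatter), beyond the scatter, whereas the step of a 1.4-fold lower number from compound 2 to compound 3 (0.13 log units; within the scatter) lies within the scatter, so compound 3 and compound 2 cannot be told apart on this read-out. Compound 4, with the structure `Cc1cc(OCc2ccccc2)c(S(C)(=O)=O)cc1C(=O)N=C(N)N`, differs from compound 3 by benzyloxy in place of phenylsulfanyl on an aromatic carbon. Within the data shown here, no measured step exchanges the sulfur link for an oxygen link or inserts a methylene between the ring and the linker. The steps that come nearest, a 2.2-fold lower number from compound 1 to compound 2 (0.34 log units; beyond the scatter) and a 3.0-fold lower number from compound 1 to compound 3 (0.48 log units; beyond the scatter), show that moving from a directly attached dichlorophenyl to a sulfur-linked phenyl changes the number only modestly, and a 1.4-fold lower number from compound 2 to compound 3 (0.13 log units; within the scatter) shows that the chlorine itself hardly matters. Compound 4 is therefore expected to stay close to compound 3, with a step of a 1.8-fold higher number from compound 3 to compound 4 (0.25 log units; within the scatter) that need not exceed the scatter. The expected value for compound 4 in this assay is 25 nM, estimated to lie between 8 nM and 80 nM.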

Compound 4, half-maximal inhibitory concentration: 28 nM
Compound 4: middle estimate off by 1.1-fold (0.05 log units), on the low side, and the stated range covers the measured number.
By their numbers in this assay, from the lowest: compounds 3, 2, 4 and 1 (each within the scatter of the next, the first and the last beyond it).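

At the aromatic carbon ortho to the methylsulfonyl group, benzyloxy in place of phenylsulfanyl gives a 2.0-fold higher number from compound 3 to compound 4 (0.30 log units; within the scatter) in this assay, so this position also tolerates an oxygen-linked group carrying a methylene before the ring. The other two steps, a 1.5-fold higher number from compound 2 to compound 4 (0.17 log units; within the scatter) and a 1.5-fold lower number from compound 1 to compound 4 (0.18 log units; within the scatter), are also within the scatter, so compound 4 cannot be told apart from any of the other three compounds, even though compound 1 and compound 3 are separated beyond it. Nothing available explains these numbers.

This single change alters both the linking atom and the length of the link, so the compounds shown cannot separate the two; phenoxy and benzylsulfanyl would do so. On these data alone, it also remains open whether an amine or a carboxylic acid at this carbon would keep the number in this range.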